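Para substituent swap on the shared core: notes

A few compounds are considered here, and "the series" means these few. Any claim that something is new, unique, unknown or untested is made for them only; others in the source may bear on it.

Measured so far in a functional assay on MLM cells (Homo sapiens) for cytotoxicity, using microsomes (a lower number here means that less compound is needed, a higher number that more compound is needed for the effect), for two compounds
- compound 1 `COc1cc(/C=C\c2ccc(C(C)(C)C)cc2)cc(OC)c1OC` gives 4.32 uM as read-out
- compound 2 `CCOc1ccc(/C=C\c2cc(OC)c(OC)c(OC)c2)cc1` gives 2.9 uM as read-out

Going by the values given here, only two numbers exist, and compound 2 at 2.9 uM lies within the scatter of compound 1 at 4.32 uM so neither can be ranked above the other.

The next compound is compound 3 `COc1cc(/C=C\c2ccc(SC)cc2)cc(OC)c1OC` which differs from compound 2 by methylsulfanyl in place of ethoxy on an aromatic carbon, para to a large group methylsulfanyl in place of ethoxy on an aromatic carbon with the rest of the structure unchanged.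

Among the compounds with values here, one measured step bears on this place: a 1.5-fold lower number from compound 1 to compound 2 (0.17 log units; within the scatter) on exchanging tert-butyl for ethoxy. That single step gives no direction, and no measurement with methylsulfanyl exists yet. No step beyond the scatter is therefore expected in this assay for this change.

The expected step is a 1.0-fold lower number from compound 2 to compound 3 (0.02 log units; within the scatter) on this reasoning.

The estimate for compound 3 is 2.8 uM with an expected range from 0.8 uM to 9 uM for now.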

Compound 3, concentration for half-maximal effect: 3.3 uM
Compound 3: the middle estimate sits 1.2-fold (0.07 log units) below what was measured; measured number inside the range.
By their numbers in this assay, from the lowest: compounds 2, 3 and 1 (each within the scatter of the next).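

In this assay, methylsulfanyl on an aromatic carbon, para to a large group, gives a 1.1-fold higher number from compound 2 to compound 3 (0.06 log units; within the scatter) and a 1.3-fold lower number from compound 1 to compound 3 (0.12 log units; within the scatter), so both new steps stay within the scatter. With a sulfur-linked group now at this place alongside the oxygen-linked ethoxy and the all-carbon tert-butyl, the read-out does not separate the three groups, and no order can be set among compounds 1, 2 and 3; this holds for these three compounds and this one assay only. No measurement at hand explains why these exchanges leave the number within the scatter.

From the compounds shown here alone, whether an amine, a carboxylic acid or a longer chain such as hexyloxy at this place would move the number beyond the scatter remains open. Also open, going by these compounds, is whether tert-butyl, ethoxy and methylsulfanyl would stay this close in a read-out other than this assay, so the present result gives no ground for preferring any one of them on the shared core.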